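Swapping an aminophenyl group for an indolyl group

This account rests on a few compounds, and the source may have more. Where it says the series, first, only, none or still open, it means among the compounds named here.

In a functional assay on NCI-H460 cells (Homo sapiens) for antiproliferative activity, read by MTT assay, with a stated time of 48 h (on this read-out lower numbers stand for stronger inhibition and higher numbers for weaker inhibition), compound 1 `COc1ccc(-c2nc3cccc(-c4cc(OC)c(OC)c(OC)c4)c3o2)cc1OC` gives > 25000 nM as its reading, which is a limit of the assay and not a number. Compound 2 `COc1cc(-c2cccc3nc(-c4ccc(N)cc4)oc23)cc(OC)c1OC` reads 310 nM while compound 3 `COc1cc(-c2cccc3nc(-c4cccc(N)c4)oc23)cc(OC)c1OC` reads 2600 nM and so holds the higher of these two numbers, making it the weaker inhibitor of the pair.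

Compound 4 `COc1cc(-c2cccc3nc(-c4ccc5cc[nH]c5c4)oc23)cc(OC)c1OC` is the next to be measured. The change 1H-indol-6-yl in place of 3-aminophenyl on an aromatic carbon puts 1H-indol-6-yl in place of 3-aminophenyl on an aromatic carbon, and the rest of compound 3 stays as it is.

Every measured step alters the group on this same carbon. Putting 3-aminophenyl in place of 4-aminophenyl gave an 8.4-fold higher number from compound 2 to compound 3 (0.92 log units; beyond the scatter) and counts as modest. Putting an aminophenyl group in place of 3,4-dimethoxyphenyl gave an at least 80-fold lower number from compound 1 to compound 2 (1.90 log units; beyond the scatter) as a large step and an at least 9.6-fold lower number from compound 1 to compound 3 (0.98 log units; beyond the scatter) as an at least modest one. So this carbon responds to what it carries, yet no measured compound has 1H-indol-6-yl there.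

Compound 3 at 2600 nM is taken as the starting point, and no step beyond the scatter is expected in this assay from it. The estimated step is a 1.3-fold lower number from compound 3 to compound 4 (0.11 log units; within the scatter) with real uncertainty in either direction. Compound 4 is expected to read about 2000 nM with an estimated range from 300 nM to 15000 nM as its upper end.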

Compound 4, half-maximal inhibitory concentration: 24 nM
The estimate for compound 4 lay 83-fold (1.92 log units) above the measured number; measured number below the stated range.
By their numbers in this assay, from the lowest: compound 4; then compound 2; then compound 3. At a limit, above all of these: compound 1.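

In this assay, 1H-indol-6-yl, which brings a five-membered aromatic ring along with the six-membered one, gives a 110-fold lower number from compound 3 to compound 4 (2.03 log units; beyond the scatter), so this carbon can carry a group with two aromatic rings and still give a far lower number than with a single aminophenyl ring. Even against the better of the two aminophenyl compounds, the change gives a 13-fold lower number from compound 2 to compound 4 (1.11 log units; beyond the scatter), which shows that an amine on a phenyl ring is not required for a low reading among these compounds. The widest step is an at least 1000-fold lower number from compound 1 to compound 4 (3.01 log units; beyond the scatter), and it rests on the reading of compound 1, which is a limit of the assay: the limit of > 25000 nM in this assay, at which 1 of the 4 values shown sits.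

The compounds shown hold the indole attached in only one way, so it remains open whether 1H-indol-5-yl would read like compound 4, and whether the indole's ring hydrogen on nitrogen matters, which a 1-methylindol-6-yl or a benzofuran-6-yl group could test. From the compounds shown here alone, the trimethoxyphenyl group is the same throughout, so it is also open whether the low reading of compound 4 would survive with a single methoxy group on that ring.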